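This account rests on a few compounds, and the source may have more. Where it says the series, first, only, none or still open, it means among the compounds named here.

In an ADME assay on a cell-free system (plasma, Homo sapiens) (on this read-out lower numbers stand for a smaller free fraction and higher numbers for a larger free fraction), compound 1 (`CCCS(=O)(=O)c1ccc(F)c(C#Cc2cc(Cl)ccc2OCC(=O)O)c1`) gives 0.01 as its result. For compound 2 (`COCCNS(=O)(=O)c1ccc(C)c(C#Cc2cc(Cl)ccc2OCC(=O)O)c1`) the entry reads "not determined" (no result reported) and so offers no number to start from. Compound 3 (`Cc1ccc(S(=O)(=O)N(C)C)cc1C#Cc1cc(Cl)ccc1OCC(=O)O`) carries dimethylamino in place of (2-methoxyethyl)amino on a sulfonyl sulfur. For the measured compounds named here, no measured step shows the size of such an exchange, so no shift beyond the usual scatter, in either direction, is expected in this assay here. Going by the values given here, the only anchor is compound 1 with its 0.01 reading. For compound 3 the estimated value is 0.01 within an expected range from 0.004 to 0.025 overall.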

Compound 3, unbound fraction: 0.004
Estimate against measurement, compound 3: 2.5-fold (0.40 log units) above, and the stated range covers the measured number.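

No new step can be read from compound 2 and compound 3 in this assay. On these data alone, what exchanging (2-methoxyethyl)amino for dimethylamino does to the unbound fraction stays open. Nothing shown offers an explanation for the reading of compound 3.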